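This account rests on a few compounds, and the source may have more. Where it says the series, first, only, none or still open, it means among the compounds named here.

In an ADME assay on a cell-free system (plasma, Rattus norvegicus) for protein binding, compound 1 (`OC[C@@H]1[C@@H](O)[C@H](O)[C@@H](O)CN1CCCCCCOc1cc(F)ccc1F`) gives 68%, and compound 2 (`OC[C@@H]1[C@@H](O)[C@H](O)[C@@H](O)CN1CCCCCCOc1cccc(C(F)(F)F)c1`) gives 90%. Of these two, compound 1 leaves the larger share of compound free, and the gap lies beyond the scatter. Compound 3 (`COc1ccccc1OCCCCCCN1C[C@H](O)[C@@H](O)[C@H](O)[C@H]1CO`) differs from compound 1 in one place, with 2-methoxyphenyl in place of 2,5-difluorophenyl on an oxygen on a saturated carbon. Among the compounds with values here, no measured pair shows this swap, so no step beyond the scatter is expected, and the estimated change is a 1.1-fold higher unbound fraction from compound 1 to compound 3 (0.04 log units; within the scatter). For compound 3, the expected value in this assay is 65%, with an estimated range from 45% to 82%.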

Compound 3, plasma protein binding in the plasma assay: 70%
Beside the measured number, compound 3's estimate is 1.2-fold (0.07 log units) (unbound fraction) above it; low and high end bracket the measured number.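

At the oxygen on a saturated carbon, 2-methoxyphenyl can replace 2,5-difluorophenyl with no visible effect on protein binding: in the plasma assay compound 1 gives 68% and compound 3 gives 70%, which is a 1.1-fold lower unbound fraction from compound 1 to compound 3 (0.03 log units; within the scatter). Within the data shown here, the earlier compounds offered no one-place comparison, so this is the first direct reading of a change at this position. The same swap also stays within the scatter for solubility, where in a physicochemical assay for solubility, in phosphate buffer, at pH 4 (on this read-out higher numbers stand for higher solubility and lower numbers for lower solubility), compound 1 gives 296000 nM and compound 3 gives 286000 nM, which is a 1.0-fold lower number from compound 1 to compound 3 (0.01 log units; within the scatter), but no evidence here explains either result. Going by these compounds, it remains open whether an amine or a carboxylic acid on the aromatic ring would leave these read-outs just as unchanged. A longer chain is equally untested among the compounds shown.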